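A small expected step from pyridin-2-yl to 4-hydroxyphenyl

A few compounds are considered here, and "the series" means these few. Any claim that something is new, unique, unknown or untested is made for them only; others in the source may bear on it.

Measured in a functional assay on HCT-116 cells (Homo sapiens) for antiproliferative activity, read by MTT assay, with a stated time of 24 h; on this read-out higher numbers stand for weaker inhibition and lower numbers for stronger inhibition:
Compound 1 `COc1ccc(C(=O)/C=C/c2cccc([N+](=O)[O-])c2)c2c1C=CC(C)(C)O2` gives 8050 nM
Compound 2 `COc1ccc(C(=O)/C=C/c2ccccn2)c2c1C=CC(C)(C)O2` gives 6630 nM

Among the measured compounds shown here, compound 2 stands level with the only other measured compound, and the two values lie within the scatter of each other. Compound 3 `COc1ccc(C(=O)/C=C/c2ccc(O)cc2)c2c1C=CC(C)(C)O2` has not yet been measured. It carries 4-hydroxyphenyl in place of pyridin-2-yl on a double-bonded chain carbon bound to a double-bonded chain carbon at that same place. For the measured compounds named here, one measured step bears on this change: a 1.2-fold lower number from compound 1 to compound 2 (0.08 log units; within the scatter) is an exchange at that place and stays within the scatter. Going by the values given here, no measured compound carries 4-hydroxyphenyl, so the range is kept wide. The estimated step of a 1.1-fold lower number from compound 2 to compound 3 (0.04 log units; within the scatter) means that no change beyond the scatter is expected in this assay here. Compound 3 is expected at 6000 nM with 2500 nM to 14000 nM as the estimated range.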

Compound 3, half-maximal inhibitory concentration: > 10000 nM
Compound 3: a limit, no number (the forecaster's own chance of this, stated with the estimate: 5%); middle value at least 1.6-fold (0.22 log units) from the limit.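

At this place, on a double-bonded chain carbon bound to a double-bonded chain carbon, the exchange of 3-nitrophenyl for pyridin-2-yl had stayed within the scatter and gave two numbers. With 4-hydroxyphenyl at the same place, compound 3 gives > 10000 nM in this assay, which is a limit of the assay and not a number. The change reads as an at least 1.5-fold higher number from compound 2 to compound 3 (0.17 log units; that floor lies within the scatter) and as an at least 1.2-fold higher number from compound 1 to compound 3 (0.09 log units; that floor lies within the scatter), so only floors are known, and the true size of either step cannot be told, because the reading ends at a limit: the limit of > 10000 nM in this assay, at which 1 of the 3 values shown sits.

The compounds shown leave open whether this place can give stronger inhibition at all. They also do not tell how a 4-methoxyphenyl, a 4-aminophenyl or a carboxylic acid would read here.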